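Adding a methyl: compound 3 to compound 4

A few compounds are considered here, and "the series" means these few. Any claim that something is new, unique, unknown or untested is made for them only; others in the source may bear on it.

Among the measured compounds shown here, in a functional assay on HeLa cells (Homo sapiens) for antiproliferative activity, read by MTT assay, with a stated time of 72 h (on this read-out higher numbers stand for weaker inhibition and lower numbers for stronger inhibition), compound 1 (`CC/C=C/C(=O)Nc1cccc(Oc2nc(Nc3ccc(OC)cc3)nc3c2CSCC3)c1`) gives 27200 nM and compound 2 (`C=CC(=O)Nc1cccc(Oc2nc(Nc3ccc(OC)nc3)nc3c2CSCC3)c1`) gives 26300 nM while compound 3 (`C/C=C/C(=O)Nc1cccc(Oc2nc(Nc3ccc(OC)nc3)nc3c2CSCC3)c1`) gives 16500 nM on the numbers so far. Compound 3 thus stands within the scatter of both other compounds.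

Compound 4 (`CC/C=C/C(=O)Nc1cccc(Oc2nc(Nc3ccc(OC)nc3)nc3c2CSCC3)c1`) differs from compound 3 by methyl in place of hydrogen on a saturated chain carbon bound to a double-bonded chain carbon in the form of methyl in place of hydrogen on a saturated chain carbon bound to a double-bonded chain carbon, which turns prop-1-en-1-yl into but-1-en-1-yl.

For the measured compounds named here, the one measured step on this chain is a 1.6-fold lower number from compound 2 to compound 3 (0.20 log units; within the scatter) and it lies within the scatter. The but-1-en-1-yl chain already occurs in compound 1 at 27200 nM with another change elsewhere in the molecule, and that value sits within the scatter of the others.

No step beyond the scatter is therefore expected in this assay from this change. The expected step is a 1.2-fold higher number from compound 3 to compound 4 (0.08 log units; within the scatter) and it should stay within the scatter. Compound 4 is estimated at 20000 nM with an expected range from 11000 nM to 36000 nM for repeat measurements.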

Compound 4, half-maximal inhibitory concentration: 31200 nM
For compound 4 the middle estimate is 1.6-fold (0.19 log units) below the measured one, within the range that was stated.
By their numbers in this assay, from the lowest: compounds 3, 2, 1 and 4 (each within the scatter of the next).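

In this assay, methyl in place of hydrogen on a saturated chain carbon bound to a double-bonded chain carbon gives a 1.9-fold higher number from compound 3 to compound 4 (0.28 log units; within the scatter) and so, at this position, turns prop-1-en-1-yl into but-1-en-1-yl without a step beyond the scatter. With the 6-methoxypyridin-3-yl group held constant, but-1-en-1-yl in place of vinyl gives a 1.2-fold higher number from compound 2 to compound 4 (0.07 log units; within the scatter) and places all three chains on this group within the scatter of one another. With but-1-en-1-yl held constant, 6-methoxypyridin-3-yl in place of 4-methoxyphenyl gives a 1.1-fold higher number from compound 1 to compound 4 (0.06 log units; within the scatter) and adds a direct reading of that exchange, also within the scatter.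

As far as these compounds go, whether a longer chain such as pent-1-en-1-yl or a dimethylaminomethyl group at this position would move the number beyond the scatter remains open. No measured evidence explains these steps.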